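A few compounds are considered here, and "the series" means these few. Any claim that something is new, unique, unknown or untested is made for them only; others in the source may bear on it.

Compound 1 `C=CCN(CC=C)Cc1c(C(F)(F)F)nc2n(-c3c(C)cc(C)cc3C)c(Cl)cn12`: in an assay on cells for displacement of a labelled ligand from corticotropin-releasing factor receptor 1 (Homo sapiens), with a stated time of 100 min (a higher number here means a weaker inhibitor, a lower number a stronger inhibitor), compound 1 gives 13 nM.
Compound 2 `CCCN(Cc1c(C(F)(F)F)nc2n(-c3c(C)cc(C)cc3C)c(Cl)cn12)CC1CCC1`: compound 2 gives 5.3 nM.
Compound 3 `CCN(CCC1CC1)Cc1c(C(F)(F)F)nc2n(-c3c(C)cc(C)cc3C)c(Cl)cn12`: compound 3 gives 13 nM.

All three share one core and differ only in the amine attached to a saturated chain carbon bound to an aromatic carbon. Compound 3 stands level with compound 1 at the digits shown, the two together giving the highest numbers of the three, with compound 2 as the only one set apart: a 2.5-fold higher number from compound 2 to compound 3 (0.39 log units; beyond the scatter), while no change at the digits printed from compound 1 to compound 3 (within the scatter).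

Compound 4 `Cc1cc(C)c(-n2c(Cl)cn3c(CN(C)Cc4ccco4)c(C(F)(F)F)nc23)c(C)c1` carries a further variation at the same place: ((furan-2-yl)methyl)(methyl)amino in place of (2-cyclopropylethyl)(ethyl)amino on a saturated chain carbon bound to an aromatic carbon. Within the data shown here, the change brings in an aromatic five-membered ring with one hetero atom and a second hydrogen-bond acceptor, which none of the measured compounds has. Among the measured compounds shown here, the steps that bear on it are those at the same position, a 2.5-fold lower number from compound 1 to compound 2 (0.39 log units; beyond the scatter) and a 2.5-fold higher number from compound 2 to compound 3 (0.39 log units; beyond the scatter), both modest, and no change at the digits printed from compound 1 to compound 3 (within the scatter). Since every amine change seen so far moved the number little, the step of a 1.2-fold higher number from compound 3 to compound 4 (0.06 log units; within the scatter) is expected to be small as well, with no clear direction, though the new ring adds some uncertainty. Compound 4 is therefore estimated at 15 nM, within a range from 5 nM to 45 nM.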

Compound 4, inhibition constant: 180 nM
The estimate for compound 4 lay 12-fold (1.08 log units) below the measured number; the measured number lies above the stated range.
By their numbers in this assay, from the lowest: compound 2; then compounds 1 and 3 (each within the scatter of the next); then compound 4.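

The ((furan-2-yl)methyl)(methyl)amino group shows that this position is less forgiving than the first three amines suggested: in this assay there is a 14-fold higher number from compound 3 to compound 4 (1.14 log units; beyond the scatter), along with a 14-fold higher number from compound 1 to compound 4 (1.14 log units; beyond the scatter) and a 34-fold higher number from compound 2 to compound 4 (1.53 log units; beyond the scatter), all large, whereas the earlier amines differed by modest steps or not at all. The size of the group, counted in heavy atoms, does not track this rise, since the group that leaves and the group that enters each have 8 heavy atoms, so that count alone does not predict the result at this place. What does differ in the count is the furan ring with its oxygen and the second hydrogen-bond acceptor, but no measurement here gives the cause of the rise.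

The change also replaces the ethyl on the amine nitrogen with methyl while swapping the cyclopropyl-bearing chain for the furan-bearing one, so compound 4 alone cannot separate the two effects. A (cyclobutylmethyl)(methyl)amino group and a ((furan-2-yl)methyl)(propyl)amino group at the same place would tell whether the methyl or the furan ring goes with the higher number.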